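Vinyl for Bromo on the Shared Core

The source may report more compounds than this note shows. Statements on the series, on what has been measured and on what is new or still open speak of the compounds shown alone.

Of the compounds shown here, two have so far been measured in an assay on HEK293 cells for binding affinity to 5-hydroxytryptamine receptor 7 (Homo sapiens), read by radioligand binding; a higher number here means a weaker inhibitor, a lower number a stronger inhibitor. Compound 1 `CN1CCCN(CCn2ccc3ccc(Br)cc32)CC1` gives 31 nM, the lowest of the two numbers. Compound 2 `CN1CCCN(CCn2ccc3cc(Br)ccc32)CC1` gives 88 nM, a higher number that lies beyond the usual scatter. Compound 3 `C=Cc1ccc2ccn(CCN3CCCN(C)CC3)c2c1` has not yet been measured; it differs from compound 1 by vinyl in place of bromo on an aromatic carbon. Going by the values given here, no measured pair shows what such a change does here. Compound 3 is therefore expected to stay close to its parent, with an expected step of a 1.3-fold higher number from compound 1 to compound 3 (0.11 log units; within the scatter) of no more than the scatter in either direction. Compound 3 is estimated at 40 nM, between 12 nM and 130 nM.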

Compound 3, inhibition constant: 109 nM
Compound 3: middle estimate off by 2.7-fold (0.44 log units), on the low side; measured number inside the range.
By their numbers in this assay, from the lowest: compound 1; then compounds 2 and 3 (each within the scatter of the next).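

Going by these compounds alone, replacing bromo with vinyl on this aromatic carbon moves the number a 3.5-fold higher number from compound 1 to compound 3 (0.55 log units; beyond the scatter) in this assay and so gives the first measured change at this place on the shared core. The step is modest, but it shows that the two groups are not interchangeable here, with bromo giving the lower number. Nothing at hand explains this difference.

As far as these compounds go, whether chloro, methoxy or ethyl at this place would stay nearer to compound 1 remains open. So does whether vinyl would cause a similar step from compound 2.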